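A group swap on a compound at the limit

This account rests on a few compounds, and the source may have more. Where it says the series, first, only, none or still open, it means among the compounds named here.

Compound 1 `CCOC(=O)c1c(-c2cc(F)cc(OC)c2)[nH]c2cc(OC)ccc2c1=O` and compound 2 `CCOC(=O)c1c(-c2cccc(Br)c2)[nH]c2cc(OC)c(F)cc2c1=O` have both been through an ADME assay on HepG2 cells (Homo sapiens) for cytotoxicity, read by luminescence, with a stated time of 72 h; a higher number here means that more compound is needed for the effect, a lower number that less compound is needed. Compound 1 gives > 21500 nM, which is a limit and not a number. Compound 2 gives > 21500 nM, which is a limit too, so it offers no exact starting point. Compound 3 `CCOC(=O)c1c(-c2cc(F)cc(OC)c2)[nH]c2cc(OC)c(F)cc2c1=O` has 3-fluoro-5-methoxyphenyl in place of 3-bromophenyl on an aromatic carbon. Compound 1 carries that same 3-fluoro-5-methoxyphenyl group and still reads > 21500 nM, so no step beyond the scatter is expected. The expected change is a step that the limit leaves unreadable from compound 2 to compound 3. For compound 3 the estimate is 25000 nM, with an expected range of 14000 nM to 45000 nM.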

Compound 3, half-maximal effective concentration: > 21500 nM
Compound 3: a limit, no number; the forecaster's own chance of this, stated with the estimate: 85%; the middle value lies beyond the limit too.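

Neither compound 1 nor compound 2 gives a readable step to compound 3, because each result is a limit and not a number: the limit of > 21500 nM in this assay, at which 3 of the 3 values shown sit.

On these data alone, the true value of each compound in this assay stays open, and so does whether either change has any effect.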